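Adding a second fluoro to a diaryl urea

The source may hold more compounds than are shown below. What is called first, only, known or untested is meant among the compounds shown, and "the series" means these compounds.

Measured so far:
compound 1, `CC(C)c1ccccc1NC(=O)N[C@H](C)c1ccccc1`, gives 101%
compound 2, `C[C@@H](NC(=O)Nc1ccccc1F)c1ccccc1`, gives 95%
compound 3, `C[C@H](NC(=O)Nc1ccccc1F)c1ccccc1`, gives 92%

All three share the same urea core and were tested in an ADME assay on the whole organism with Oryza sativa as the target, tested at 1 uM; a higher number here means a weaker effect of the compound at the concentration tested, a lower number a stronger effect. Compound 2 stands second highest of the three numbers, with compound 3 nearest and compound 1 furthest, and both gaps lie within the scatter, so the three cannot be ranked against each other.

The step from compound 2 to compound 4, `C[C@@H](NC(=O)Nc1c(F)cccc1F)c1ccccc1`, is this: fluoro in place of hydrogen on an aromatic carbon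

The measured step that bears on it most is the one changing the same ring, where a number 6 percentage points lower from compound 1 to compound 2 (within the scatter). The other step, a number 3 percentage points lower from compound 2 to compound 3 (within the scatter), concerns only the configuration at the chain carbon and is noted as such (the fact that compounds 2 and 3 differ only in the configuration as drawn); it says little about a second fluoro on the ring. Neither step reached beyond the scatter, and a fluoro already sits on that ring in compound 2 without setting it apart from compound 1. Compound 4 is therefore expected to show a step of a number 2 percentage points lower from compound 2 to compound 4 (within the scatter), that is, no shift beyond the scatter. Compound 4 is estimated at 93%, with a range from 80% to 105%.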

Compound 4, a percentage reported as activity, at one concentration (the size of the read-out at that concentration, not a potency): 100%
The estimate for compound 4 lay 7 percentage points below the measured number, within the range that was stated.
By their numbers in this assay, from the lowest: compounds 3, 2, 4 and 1 (each within the scatter of the next).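

In this assay, putting fluoro in place of hydrogen on this aromatic carbon, ortho to a large group and meta to a fluoro group, gives a step that stays within the usual variation between repeats (a number 5 percentage points higher from compound 2 to compound 4 (within the scatter)). The earlier compounds changed only one substituent on this ring and the configuration at the chain carbon, so compound 4 is the first shown here with a group on this second carbon, and this single fluoro does not separate it from compound 2. The information at hand says nothing about why the step is this small, since the one available fact concerns configuration rather than this ring.

As far as these compounds go, what a group larger than fluoro would do on this same carbon remains open, for example a methoxy group, a chloro group or a longer chain, and so does the effect of an amine or a carboxylic acid there. Going by these compounds alone, also open is whether the second fluoro would give a similar step in the opposite configuration at the chain carbon, the one drawn in compound 3.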